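This account rests on a few compounds, and the source may have more. Where it says the series, first, only, none or still open, it means among the compounds named here.

Measured in an ADME assay on MRC5 cells (Homo sapiens), read by MTT assay, with a stated time of 72 h; on this read-out higher numbers stand for weaker inhibition and lower numbers for stronger inhibition:
- compound 1 `CNc1ncnc2c1c(-c1cccs1)cn2[C@@H]1O[C@H](CO)[C@@H](O)[C@H]1O`: > 100000 nM
- compound 2 `Nc1nc(N)c2c(-c3cccs3)cn([C@@H]3O[C@H](CO)[C@@H](O)[C@H]3O)c2n1`: > 100000 nM
- compound 3 `Cc1nc(N)c2c(-c3cccs3)cn([C@@H]3O[C@H](CO)[C@@H](O)[C@H]3O)c2n1`: > 100000 nM

All three entries are limits of the assay and not numbers. Compound 3 gives > 100000 nM, which is such a limit. Across the series, the picture is simple: the limit of > 100000 nM in this assay, at which 3 of the 3 values shown sit.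

Compound 4 `C#Cc1cn([C@@H]2O[C@H](CO)[C@@H](O)[C@H]2O)c2nc(C)nc(N)c12` has ethynyl in place of thiophen-2-yl on an aromatic carbon. The three measured compounds all carry thiophen-2-yl, so none of them shows what this exchange does. Among the compounds with values here, the only measured step, a step that the two limits leave unreadable from compound 2 to compound 3, is a different change and gives no size to carry over. Any expectation is therefore loose. In this assay, only a move toward lower numbers, meaning stronger inhibition, could appear as a real number, and a result that stays at the limit remains quite likely. The expected move is an at least 2.0-fold lower number from compound 3 to compound 4 (0.30 log units; that floor lies within the scatter). Compound 4 is estimated at 50000 nM, with an expected range of 5000 nM to 100000 nM.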

Compound 4, half-maximal inhibitory concentration: > 100000 nM
Compound 4 ended at the assay's limit (the forecaster's own chance of this, stated with the estimate: 55%); at least 2.0-fold (0.30 log units) between middle value and limit.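

Within the data shown here, compound 3 and compound 4 both end at a limit and not at a number, so the exchange of thiophen-2-yl for ethynyl gives no step that can be read. The compounds shown leave open which change to the shared core, if any, would yield a real number.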